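Ortho-substituted aryl variants of the thiosemicarbazone series

A few compounds are considered here, and "the series" means these few. Any claim that something is new, unique, unknown or untested is made for them only; others in the source may bear on it.

Compound 3 (`CC1=CC[C@@H]([C@@](C)(O)CCCC(C)(C)NC(=S)N/N=C\c2ccc([N+](=O)[O-])cc2)CC1`) sits at the upper end of what has been measured. In a functional assay on OVCAR-3 cells (Homo sapiens) for cytotoxicity, read by sulforhodamine B assay (on this read-out higher numbers stand for lower toxicity in this test and lower numbers for higher toxicity in this test), compound 3 gives > 100000 nM, which is a limit of the assay and not a number. Compound 1 (`CC1=CC[C@@H]([C@@](C)(O)CCCC(C)(C)NC(=S)N/N=C\c2ccc(N(C)C)cc2)CC1`) gives > 100000 nM in this assay, likewise a limit. For the measured compounds named here, compound 2 (`CC1=CC[C@@H]([C@@](C)(O)CCCC(C)(C)NC(=S)N/N=C\c2ccccc2[N+](=O)[O-])CC1`) gives 41900 nM in this assay, the only real number among the three, and the change an at least 2.3-fold higher number from compound 2 to compound 3 (0.37 log units; beyond the scatter) is the one that bears directly on the present step. Compound 4 (`CC1=CC[C@@H]([C@@](C)(O)CCCC(C)(C)NC(=S)N/N=C\c2ccccc2Cl)CC1`) differs from compound 3 by 2-chlorophenyl in place of 4-nitrophenyl on a carbon with a double bond to nitrogen, so compound 4 again carries its group on the 2-position of the phenyl ring, as compound 2 does. The step of an at least 2.3-fold lower number from compound 1 to compound 2 (0.37 log units; beyond the scatter) points the same way. The change from compound 3 to compound 4 is therefore expected to bring a lower number in this assay, with an at least 2.0-fold lower number from compound 3 to compound 4 (0.30 log units; that floor lies within the scatter) as the estimated size, though compound 3 sits at the limit of > 100000 nM in this assay, at which 2 of the 3 values shown sit, and the true size of the step cannot be read. Compound 4 is thus expected to give about 50000 nM in this assay, within 15000 nM to 100000 nM.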

Compound 4, concentration lethal to 50% of the cells: > 100000 nM
Compound 4: only a limit was reported; the forecaster's own chance of this, stated with the estimate: 40%; at least 2.0-fold (0.30 log units) between middle value and limit.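

In this assay compound 4 gives > 100000 nM, which is a limit of the assay and not a number. Chloro in place of nitro on an aromatic carbon gives an at least 2.3-fold higher number from compound 2 to compound 4 (0.37 log units; beyond the scatter), so 2-chlorophenyl does not share the real number seen with 2-nitrophenyl, and among the compounds shown, carrying a group at this ring position does not by itself bring a value under the limit. The steps from compound 1 to compound 4 and from compound 3 to compound 4 cannot be read, because both ends of each rest on the same ceiling: the limit of > 100000 nM in this assay, at which 3 of the 4 values shown sit.

As far as these compounds go, whether 2-methoxyphenyl or 2-aminophenyl would give a real number stays open. Also open, from the compounds shown here alone, is how far compound 1, compound 3 and compound 4 stand from one another beyond the limit.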